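The source may hold more compounds than are shown below. What is called first, only, known or untested is meant among the compounds shown, and "the series" means these compounds.

Three compounds from this series share a core and differ only in the substituent on a benzyl group attached to an aromatic nitrogen. Compound 1 `N#Cc1ccc(Cn2c(/C=C3\SC(=S)N(CC(=O)O)C3=O)nc3ccccc32)cc1` carries a cyano group; in a functional assay on MDA-MB-231 cells (Homo sapiens) for cytotoxicity, read by MTT assay, with a stated time of 48 h (a higher number here means a weaker inhibitor, a lower number a stronger inhibitor), compound 1 gives 11200 nM. Compound 2 `O=C(O)CN1C(=O)/C(=C/c2nc3ccccc3n2Cc2ccc(F)cc2)SC1=S` carries fluoro in its place and gives 2620 nM, while compound 3 `Cc1ccc(Cn2c(/C=C3\SC(=S)N(CC(=O)O)C3=O)nc3ccccc32)cc1` carries methyl and gives 1040 nM. Compound 1 therefore stands as the weakest of the three measured compounds, with both neighbours giving lower numbers: a 4.3-fold lower number from compound 1 to compound 2 (0.63 log units; beyond the scatter), and an 11-fold lower number from compound 1 to compound 3 (1.03 log units; beyond the scatter). Between the two substituted analogues, a 2.5-fold lower number from compound 2 to compound 3 (0.40 log units; beyond the scatter).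

Compound 4 `O=C(O)CN1C(=O)/C(=C/c2nc3ccccc3n2Cc2ccccc2F)SC1=S` has not yet been measured. It differs from compound 1 as follows: 2-fluorophenyl in place of 4-cyanophenyl on a saturated chain carbon bound to an aromatic nitrogen. The step from compound 1 to compound 2 also exchanges fluoro for cyano on an aromatic carbon, but the 2-fluorophenyl group of compound 4 is not the same group as the fluorophenyl of compound 2, so the earlier step is only a guide. A lowering of similar size is expected, a 3.7-fold lower number from compound 1 to compound 4 (0.57 log units; beyond the scatter), though with wider uncertainty than the measured step. Compound 4 is estimated to give 3000 nM, expected to lie between 1200 nM and 8000 nM.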

Compound 4, half-maximal inhibitory concentration: 330 nM
Compound 4: middle estimate off by 9.1-fold (0.96 log units), on the high side, and the stated range ends above it.
By their numbers in this assay, from the lowest: compound 4; then compound 3; then compound 2; then compound 1.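

In this assay, the most informative step is a 7.9-fold lower number from compound 2 to compound 4 (0.90 log units; beyond the scatter): 4-fluorophenyl and 2-fluorophenyl hold the same atoms and differ only in where the fluoro sits on the ring, so at this position the placement of a substituent matters as well as its identity, something that 4-cyanophenyl, 4-fluorophenyl and 4-methylphenyl alone could not show. The 2-fluorophenyl group also outdoes the best of those three groups, with a 3.2-fold lower number from compound 3 to compound 4 (0.50 log units; beyond the scatter), and the distance from the cyano compound grows to a 34-fold lower number from compound 1 to compound 4 (1.53 log units; beyond the scatter), so compound 4 is the strongest of the four and the order among the earlier groups gave no hint of this result. Nothing available here explains why moving the fluoro changes the number so much.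

These compounds leave open whether the gain belongs to fluoro specifically or would also appear with a chloro or methoxy group in place of the fluoro of compound 4. They also leave open how an unsubstituted phenyl group would compare, which would show whether the 2-fluoro group improves on the bare ring or the 4-substituents simply weaken it.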